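The source may hold more compounds than are shown below. What is called first, only, known or untested is meant among the compounds shown, and "the series" means these compounds.

Measured so far:
- compound 1 `CN(C)CCCCCn1c2c(c3ccccc31)C(=O)c1c[n+]([O-])c3ccccc3c1C2=O`: 470 nM
- compound 2 `O=C1c2c[n+]([O-])c3ccccc3c2C(=O)c2c1c1ccccc1n2Cc1cn(C[C@H](O)CO)nn1`: 400 nM

Not yet measured:
- compound 3 `CN1CCN(CCCCn2c3c(c4ccccc42)C(=O)c2c[n+]([O-])c4ccccc4c2C3=O)CC1`

In a functional assay on HCT-116 cells (Homo sapiens) for cytotoxicity, read by MTT assay, with a stated time of 72 h (on this read-out higher numbers stand for weaker inhibition and lower numbers for stronger inhibition), compound 2 gives 400 nM and stands level with compound 1 once the scatter is allowed for. The next comparison runs from compound 2 to compound 3: 3-(4-methylpiperazin-1-yl)propyl in place of 1-(2,3-dihydroxypropyl)-1H-1,2,3-triazol-4-yl on a saturated chain carbon bound to an aromatic nitrogen. In words, this is 3-(4-methylpiperazin-1-yl)propyl in place of 1-(2,3-dihydroxypropyl)-1H-1,2,3-triazol-4-yl on a saturated chain carbon bound to an aromatic nitrogen.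

Going by the values given here, one measured step bears on this change: a 1.2-fold lower number from compound 1 to compound 2 (0.07 log units; within the scatter). That step also exchanged a side chain on the same kind of carbon, replacing 4-(dimethylamino)butyl with the triazolyl group that now leaves. It stayed within the scatter, so it gives no reason to expect a shift in either direction, although one step is thin evidence and the piperazine ring itself has not been tested. No change beyond the scatter is therefore expected in this assay, and the expected step is a 1.1-fold higher number from compound 2 to compound 3 (0.05 log units; within the scatter). For compound 3 the estimated value is 450 nM, with an expected range of 170 nM to 1200 nM.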

Compound 3, half-maximal inhibitory concentration: 10 nM
Beside the measured number, compound 3's estimate is 45-fold (1.65 log units) above it, outside the stated range (below it).
By their numbers in this assay, from the lowest: compound 3; then compounds 2 and 1 (each within the scatter of the next).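

The side chain on the saturated chain carbon bound to an aromatic nitrogen can move the number in this assay far beyond the scatter, as shown by a 40-fold lower number from compound 2 to compound 3 (1.60 log units; beyond the scatter), which the earlier exchange at this place, a 1.2-fold lower number from compound 1 to compound 2 (0.07 log units; within the scatter), gave no sign of. The step of a 47-fold lower number from compound 1 to compound 3 (1.67 log units; beyond the scatter) locates the change further out, with 4-methylpiperazin-1-yl in place of (dimethylamino)methyl on a saturated chain carbon, four bonds along the chain from an aromatic nitrogen; a terminal amine as such is therefore not enough, since compound 1 carries a dimethylamino group and gives 470 nM. Nothing at hand explains the size of this gain.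

The compounds shown do not separate the contribution of the piperazine ring from that of its methyl group, a question that a terminal morpholin-4-yl or an unsubstituted piperazin-1-yl on the same chain would address. As far as these compounds go, it also remains open whether the gain persists on a shorter or longer chain, such as a propyl or hexyl linker carrying the same 4-methylpiperazin-1-yl group.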